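The source may hold more compounds than are shown below. What is called first, only, known or untested is meant among the compounds shown, and "the series" means these compounds.

Of the compounds shown here, two have been measured so far in a functional assay on SW1573 cells (Homo sapiens) for antiproliferative activity, read by sulforhodamine B assay, with a stated time of 48 h; a lower number here means a stronger inhibitor of growth, a higher number a weaker inhibitor of growth. Compound 1 `CC(C)(C)[Si](C)(C)O[C@@H]1CCCO[C@@H]1/C=C/C(=O)OCc1ccccc1` gives 37000 nM, while compound 2 `COC(=O)/C=C\[C@H]1OCCC[C@H]1O[Si](C)(C)C(C)(C)C` gives 6300 nM, the lower of the two numbers, and the gap between them lies beyond the usual scatter. Compound 3 `COC(=O)/C=C/[C@H]1OCCC[C@H]1O[Si](C)(C)C(C)(C)C` differs from compound 2 only in configuration: a double bond is drawn Z in compound 2 and E in compound 3 (the two compounds have the same atoms and bonds and differ only in configuration as drawn: 1 of 3 stereo elements differ; a double bond is drawn Z in compound 2 and E in compound 3). Within the data shown here, no measured pair shows a change of this kind, so any expectation is tentative. Among the measured compounds shown here, with compound 2 holding the lower of only two numbers at 6300 nM, a moderate move to a higher number, meaning weaker growth inhibition, seems more likely than a move to a lower one, although a step within the scatter remains possible. The expected size is a 1.9-fold higher number from compound 2 to compound 3 (0.28 log units; within the scatter). For compound 3 the estimated value is 12000 nM, with an expected range of 4000 nM to 35000 nM.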

Compound 3, concentration for 50% growth inhibition: > 100000 nM
Compound 3: a limit, no number; the forecaster's own chance of this, stated with the estimate: 5%; middle value at least 8.3-fold (0.92 log units) from the limit.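

In this assay compound 3 gives > 100000 nM, which is a limit of the assay and not a number. Drawing the double bond E rather than Z gives an at least 15-fold higher number from compound 2 to compound 3 (1.20 log units; beyond the scatter), so the geometry of this one bond matters greatly for growth inhibition, and the comparison is a clean one: the fact that compounds 2 and 3 differ only in the configuration as drawn. With the double bond drawn E in both compounds, hydrogen in place of phenyl on a saturated chain carbon bound to an oxygen next to a carbonyl group gives an at least 2.7-fold higher number from compound 1 to compound 3 (0.43 log units; beyond the scatter), so the phenyl also counts in this series.

Going by these compounds, both steps rest on a limit, so their true sizes remain unknown. Also open, on these data alone, are how a Z double bond behaves with the phenyl present, and whether a carboxylic acid or an amide in place of the ester retains growth inhibition.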